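Lengthening a side chain on a shared core

The compounds below may be only part of what the source reports. "The series", "measured", "known", "first", "only" and "open" are said of these compounds alone.

In a functional assay on MCF7 cells (Homo sapiens) for cytotoxicity, read by CellTiter-Glo, with a stated time of 5 days (a higher number here means a weaker inhibitor, a lower number a stronger inhibitor), compound 2 `CC/C(=C(/c1ccc(/C=C/C(=O)O)cc1)c1ccc2[nH]ncc2c1)c1ccccc1` gives 7.2 nM, the lowest number of the three measured compounds. Compound 1 `C/C(=C(/c1ccc(/C=C/C(=O)O)cc1)c1ccc2[nH]ncc2c1)c1ccccc1` gives 40 nM, and compound 3 `CCC/C(=C(/c1ccc(/C=C/C(=O)O)cc1)c1ccc2[nH]ncc2c1)c1ccccc1` gives 11 nM. The step of a 5.6-fold lower number from compound 1 to compound 2 (0.74 log units; beyond the scatter) and the step of a 3.6-fold lower number from compound 1 to compound 3 (0.56 log units; beyond the scatter) both lowered the number, whereas the step of a 1.5-fold higher number from compound 2 to compound 3 (0.18 log units; within the scatter) stayed within the scatter. Compound 4 `CCCC/C(=C(/c1ccc(/C=C/C(=O)O)cc1)c1ccc2[nH]ncc2c1)c1ccccc1` differs from compound 2 by ethyl in place of hydrogen on a saturated chain carbon, two bonds along the chain from a double-bonded chain carbon. The change from compound 2 to compound 3 sits at the same place and changed little, so no step beyond the scatter is expected in this assay for this further lengthening. Compound 4 is therefore expected to give about 12 nM, estimated between 5 nM and 30 nM, the expected step being a 1.7-fold higher number from compound 2 to compound 4 (0.22 log units; within the scatter).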

Compound 4, half-maximal inhibitory concentration: 10 nM
For compound 4 the middle estimate is 1.2-fold (0.08 log units) above the measured one; the range from low to high includes it.
By their numbers in this assay, from the lowest: compounds 2, 4 and 3 (each within the scatter of the next); then compound 1.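

In this assay the chain at this position levels off: the steps of a 1.4-fold higher number from compound 2 to compound 4 (0.14 log units; within the scatter) and a 1.1-fold lower number from compound 3 to compound 4 (0.04 log units; within the scatter) show no gain from further length, whereas a 4.0-fold lower number from compound 1 to compound 4 (0.60 log units; beyond the scatter) remains. The gain is confined to steps away from compound 1, and the methyl change does not carry over from one core to another: the same change on two cores in this assay, a 5.6-fold lower number (0.74 log units; beyond the scatter) from compound 1 to compound 2 and a 1.1-fold lower number (0.04 log units; within the scatter) from compound 3 to compound 4, 5.1-fold (0.70 log units) apart, beyond the scatter of two such steps. The ethyl change behaves in the same way: the same change on two cores in this assay, a 3.6-fold lower number (0.56 log units; beyond the scatter) from compound 1 to compound 3 and a 1.4-fold higher number (0.14 log units; within the scatter) from compound 2 to compound 4, 5.1-fold (0.70 log units) apart, beyond the scatter of two such steps. The compounds shown leave open whether a pentyl chain, a branched isopropyl group or a chain ending in a hydroxyl group would stay level with compound 2.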